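A few compounds are considered here, and "the series" means these few. Any claim that something is new, unique, unknown or untested is made for them only; others in the source may bear on it.

In a functional assay on a cell-free system (plasma, Homo sapiens) for inhibition, with Plasma (Rattus norvegicus) as the target (a higher number here means a weaker inhibitor, a lower number a stronger inhibitor), compound 1 `O=C(O)CCNC(=O)c1cccc(C(=O)Nc2ccc3c(c2)CNCC3)c1` gives 78 nM, compound 2 `O=C(O)CC(NC(=O)c1cccc(C(=O)Nc2ccc3c(c2)CNCC3)c1)c1ccccc1` gives 25 nM, and compound 3 `O=C(O)CCNC(=O)c1cc(C(=O)Nc2ccc3c(c2)CNCC3)cc([N+](=O)[O-])c1` gives 2300 nM. Compound 3 therefore has the highest number of the three and is the weakest inhibitor measured so far. Compound 4 `O=C(O)CC(NC(=O)c1cc(C(=O)Nc2ccc3c(c2)CNCC3)cc([N+](=O)[O-])c1)c1ccccc1` has not yet been measured and differs from compound 3 by one change: phenyl in place of hydrogen on a saturated chain carbon bound to an amide-type nitrogen and a saturated chain carbon. This change turns 2-carboxyethyl into 2-carboxy-1-phenylethyl.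

The same change has been measured once, in the absence of the nitro group: a 3.1-fold lower number from compound 1 to compound 2 (0.49 log units; beyond the scatter). This modest step runs towards a stronger inhibitor. The other measured step, a 29-fold higher number from compound 1 to compound 3 (1.47 log units; beyond the scatter), is large, but it concerns nitro in place of hydrogen and bears only on where compound 3 starts. Among the compounds with values here, only one pair shows the phenyl change, and the data do not show whether it carries over when nitro is present. A modest step in the same direction is therefore expected in this assay, although it could fall within the scatter. The expected step is a 3.1-fold lower number from compound 3 to compound 4 (0.49 log units; beyond the scatter). For compound 4 the estimated value is 750 nM, with an expected range from 250 nM to 2300 nM.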

Compound 4, half-maximal inhibitory concentration: 710 nM
Beside the measured number, compound 4's estimate is 1.1-fold (0.02 log units) above it; the range from low to high includes it.
By their numbers in this assay, from the lowest: compound 2; then compound 1; then compound 4; then compound 3.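

In this assay, phenyl in place of hydrogen on the saturated chain carbon still lowers the number when nitro is present, a 3.2-fold lower number from compound 3 to compound 4 (0.51 log units; beyond the scatter), so the change carries over to the nitro-bearing core and keeps its size: the same change on two cores in this assay, a 3.1-fold lower number (0.49 log units; beyond the scatter) from compound 1 to compound 2 and a 3.2-fold lower number (0.51 log units; beyond the scatter) from compound 3 to compound 4, 1.0-fold (0.02 log units) apart, within the scatter of two such steps

The nitro change, previously read only on the 2-carboxyethyl compounds, can now be read on the 2-carboxy-1-phenylethyl pair as well, a 28-fold higher number from compound 2 to compound 4 (1.45 log units; beyond the scatter), and its large penalty persists with phenyl in place: the same change on two cores in this assay, a 29-fold higher number (1.47 log units; beyond the scatter) from compound 1 to compound 3 and a 28-fold higher number (1.45 log units; beyond the scatter) from compound 2 to compound 4, 1.0-fold (0.02 log units) apart, within the scatter of two such steps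

Across these four compounds, each change therefore has the same size whether or not the other is present, and no compound goes against this, although the pattern rests on a single set of two changes.

The compounds shown leave open whether the same independence holds for methyl or a substituted phenyl such as 4-fluorophenyl on that saturated chain carbon. They also leave open whether an amine or a methoxy group in place of nitro on the aromatic carbon would give a step of similar size, or whether a longer chain such as 3-carboxypropyl would keep the phenyl step.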